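This account rests on a few compounds, and the source may have more. Where it says the series, first, only, none or still open, it means among the compounds named here.

In a functional assay on MCF7 cells (Homo sapiens) for cytotoxicity, read by MTT assay, with a stated time of 24 h (a lower number here means a stronger inhibitor, a higher number a weaker inhibitor), the measured compounds are:

- Compound 1 `C#CCn1c(=O)c(C=O)cc2cc(C)ccc21` gives > 100000 nM (a limit of the assay, not a number)
- Compound 2 `C=CCn1c(=O)c(/C=C/C(=O)/C=C(O)/C=C/c2ccc(O)c(OC)c2)cc2ccccc21` gives 23500 nM
- Compound 3 `C#CCn1c(=O)c(/C=C/C(=O)/C=C(O)/C=C/c2ccc(O)c(OC)c2)cc2ccccc21` gives 15000 nM

Compound 3 has a measured number alongside only compound 2, and the two sit within the scatter of each other (a 1.6-fold lower number from compound 2 to compound 3 (0.19 log units; within the scatter)). Compound 4 `C#CCn1c(=O)c(/C=C/C(=O)/C=C(O)/C=C/c2ccc(O)c(OC)c2)cc2cc(F)ccc21` differs from compound 3 by fluoro in place of hydrogen on an aromatic carbon. For the measured compounds named here, that one measured step changed a different place, the chain on the aromatic nitrogen, so no measured step tests this change directly. No shift beyond the scatter is therefore expected in this assay, and the expected step is small (a 1.1-fold lower number from compound 3 to compound 4 (0.03 log units; within the scatter)). Compound 4 is estimated at about 14000 nM (expected range 6000 nM to 35000 nM).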

Compound 4, half-maximal inhibitory concentration: 25000 nM
The estimate for compound 4 lay 1.8-fold (0.25 log units) below the measured number, within the range that was stated.
By their numbers in this assay, from the lowest: compounds 3, 2 and 4 (each within the scatter of the next). At a limit, above all of these: compound 1.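

Fluoro in place of hydrogen on an aromatic carbon is the first change at this position with a measured step in this assay, and it gives a 1.7-fold higher number from compound 3 to compound 4 (0.22 log units; within the scatter). A single fluorine here therefore moves the number no further than repeat measurements would be expected to. Nothing measured here bears on the cause of this small step.

As far as these compounds go, whether a chlorine or an amine at this position would shift the number beyond the scatter remains open. Also open, from the compounds shown here alone, is whether fluoro would behave the same way with the vinyl-bearing chain of compound 2.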